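This account rests on a few compounds, and the source may have more. Where it says the series, first, only, none or still open, it means among the compounds named here.

Measured so far in an assay on isolated protein for inhibition of glutathione S-transferase Mu 2 (Homo sapiens), with a stated time of 10 min; on this read-out lower numbers stand for stronger inhibition and higher numbers for weaker inhibition:

Compound 1 `O=C(O)CCC(=O)OCCCCCCSc1ccc([N+](=O)[O-])c2nonc12`: 160 nM
Compound 2 `Cc1ccccc1NC(=O)CCC(=O)OCCCCCCSc1ccc([N+](=O)[O-])c2nonc12`: 440 nM
Compound 3 `Cc1ccc(NC(=O)CCC(=O)OCCCCCCSc2ccc([N+](=O)[O-])c3nonc23)cc1`: 390 nM

Compound 3 sits second highest of the three numbers; the nearer step is a 1.1-fold lower number from compound 2 to compound 3 (0.05 log units; within the scatter), the further one a 2.4-fold higher number from compound 1 to compound 3 (0.39 log units; beyond the scatter). Compound 4 `O=C(CCC(=O)N1CCOCC1)OCCCCCCSc1ccc([N+](=O)[O-])c2nonc12` is not yet measured; it differs from compound 3 as follows: morpholin-4-yl in place of (4-methylphenyl)amino on a carbonyl carbon. Both amide-forming steps bear on this, a 2.8-fold higher number from compound 1 to compound 2 (0.44 log units; beyond the scatter) and a 2.4-fold higher number from compound 1 to compound 3 (0.39 log units; beyond the scatter), and they show the two amides close together. Within the data shown here, no step covers a non-aromatic ring on the carbonyl carbon, so the expectation for compound 4 rests on the amides staying near one another, giving an expected step of a 1.2-fold higher number from compound 3 to compound 4 (0.06 log units; within the scatter) in this assay. Compound 4 is therefore estimated at 450 nM, with a range of 200 nM to 1000 nM.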

Compound 4, half-maximal inhibitory concentration: 170 nM
Compound 4: the middle estimate sits 2.6-fold (0.42 log units) above what was measured, outside the stated range (below it).
By their numbers in this assay, from the lowest: compounds 1 and 4 (each within the scatter of the next); then compounds 3 and 2 (each within the scatter of the next).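

In this assay the lower numbers at this carbonyl carbon are not confined to the free acid: morpholin-4-yl gives a 2.3-fold lower number from compound 3 to compound 4 (0.36 log units; beyond the scatter) and a 2.6-fold lower number from compound 2 to compound 4 (0.41 log units; beyond the scatter), while a 1.1-fold higher number from compound 1 to compound 4 (0.03 log units; within the scatter) stays within the scatter. The higher numbers of compound 2 and compound 3 are therefore not shared by every amide here, and this change removes the amide hydrogen and the aromatic ring together. No available evidence explains the difference.

Going by these compounds, it remains open which part of the change matters. Piperidin-1-yl or dimethylamino on the same carbonyl carbon would help separate the ring oxygen, the ring itself and the amide hydrogen.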